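Working notes on a small cytotoxicity series

This account rests on a few compounds, and the source may have more. Where it says the series, first, only, none or still open, it means among the compounds named here.

In a functional assay on HepG2 cells (Homo sapiens) for cytotoxicity, read by sulforhodamine B assay, with a stated time of 48 h (on this read-out higher numbers stand for weaker inhibition and lower numbers for stronger inhibition), the two measured compounds stand as follows:

compound 1 `SC1=NNCC(n2c(-c3ccco3)nc3ccccc32)=N1` gives 62100 nM
compound 2 `Cc1ccc(-c2nc3ccccc3[nH]2)o1` gives 103000 nM

Compound 1 carries the lower of the two numbers in this assay, but its gap to compound 2 lies within the usual scatter, so no order between the two is claimed and neither is called the more active. Going by the values given here, no pair of measured compounds differs in only one place, so there is no measured step to lean on for the next compound.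

Compound 3 `N=C1N=C(n2c(-c3ccco3)nc3ccccc32)CN1` is not yet measured. It differs from compound 1 as follows: a group of 6 heavy atoms (3 carbon, 3 nitrogen; one five-membered non-aromatic ring with 2 hetero atoms) in place of a group of 7 heavy atoms (3 carbon, 3 nitrogen, 1 sulfur; one six-membered non-aromatic ring with 3 hetero atoms), on an aromatic nitrogen. The measured data give no indication of how this change acts; both measured compounds sit at high concentrations in this assay, and the change is confined to the group on the aromatic nitrogen. Compound 3 is therefore expected to stay close to compound 1, with an expected step of a 1.1-fold higher number from compound 1 to compound 3 (0.05 log units; within the scatter) that does not go beyond the scatter in either direction. Compound 3 is estimated at 70000 nM, with a range from 25000 nM to 200000 nM, and a limit rather than a number is possible at these levels.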

Compound 3, half-maximal inhibitory concentration: 63500 nM
The estimate for compound 3 lay 1.1-fold (0.04 log units) above the measured number; the range from low to high includes it.
By their numbers in this assay, from the lowest: compounds 1, 3 and 2 (each within the scatter of the next).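

Working notes, continued. In this assay, the series now has its first measured step on the aromatic nitrogen: replacing the six-membered non-aromatic ring with 3 hetero atoms by the five-membered non-aromatic ring with 2 hetero atoms gives a 1.0-fold higher number from compound 1 to compound 3 (0.01 log units; within the scatter). This exchange removes the sulfur and one ring size with it, and the hydrogen-bond acceptors counted on the group go from 3 to 1 while the donors stay at 2, yet the read-out shows no change beyond the scatter, so at this place these two ring groups cannot be told apart. Nothing measured on these compounds bears on why the two groups read alike.

Going by these compounds, whether this place tolerates groups of a different kind stays open, since only these two non-aromatic rings have been compared there, and a simple amine or a longer chain on the aromatic nitrogen could read differently. On these data alone, the furan-2-yl group is shared by compound 1 and compound 3, so what a change at that group would do in this assay also remains open.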